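The compounds below may be only part of what the source reports. "The series", "measured", "known", "first", "only" and "open" are said of these compounds alone.

In a functional assay on HepG2 cells (Homo sapiens) for cytotoxicity, read by MTT assay, with a stated time of 48 h (a lower number here means a stronger inhibitor, a higher number a weaker inhibitor), compound 1 (`O=C1/C(=C\c2ccccc2)S/C(=N/c2ccccc2)N1Cc1ccncc1`) gives 25200 nM, compound 2 (`Cc1ccc(/C=C2/S/C(=N/c3ccccc3)N(Cc3ccncc3)C2=O)cc1`) gives 19700 nM and compound 3 (`COc1cc(/C=C2/S/C(=N/c3ccccc3)N(Cc3ccncc3)C2=O)ccc1O`) gives 28600 nM. Compound 3 thus stands within the scatter of both others. Compound 4 (`COc1ccc(OC)c(/C=C2/S/C(=N/c3ccccc3)N(Cc3ccncc3)C2=O)c1`) carries 2,5-dimethoxyphenyl in place of 4-hydroxy-3-methoxyphenyl on a double-bonded chain carbon bound to a double-bonded ring carbon. The measured steps that alter this same aryl group are a 1.1-fold higher number from compound 1 to compound 3 (0.05 log units; within the scatter), a 1.5-fold higher number from compound 2 to compound 3 (0.16 log units; within the scatter) and a 1.3-fold lower number from compound 1 to compound 2 (0.11 log units; within the scatter), and all of them stayed within the scatter. No change beyond the scatter is therefore expected, and the estimated step is a 1.2-fold lower number from compound 3 to compound 4 (0.08 log units; within the scatter). In this assay, the expected value for compound 4 is 24000 nM, with an estimated range of 12000 nM to 45000 nM.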

Compound 4, half-maximal inhibitory concentration: 35800 nM
Estimate against measurement, compound 4: 1.5-fold (0.17 log units) below, within the range that was stated.
By their numbers in this assay, from the lowest: compounds 2, 1, 3 and 4 (each within the scatter of the next).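

In this assay, the new aryl group gives a 1.3-fold higher number from compound 3 to compound 4 (0.10 log units; within the scatter), a 1.8-fold higher number from compound 2 to compound 4 (0.26 log units; within the scatter) and a 1.4-fold higher number from compound 1 to compound 4 (0.15 log units; within the scatter), so all four aryl groups at this place lie within the scatter of one another. The 2,5-dimethoxyphenyl group has no hydrogen-bond donor, whereas the 4-hydroxy-3-methoxyphenyl group has one, and this difference also produces no step beyond the scatter. No independent evidence bears on this result.

As far as these compounds go, whether an amine or a carboxylic acid on this aryl ring would produce a step beyond the scatter remains open, as does the effect of changes elsewhere on the shared core.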